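Propyl in Place of 4-Methylphenyl on the Amide

A few compounds are considered here, and "the series" means these few. Any claim that something is new, unique, unknown or untested is made for them only; others in the source may bear on it.

Compound 1 `CN1CCC(c2c[nH]c3ccc(NC(=O)C4CC4)nc23)CC1` gives 9.8 nM in an assay for binding affinity to 5-hydroxytryptamine receptor 1F (Homo sapiens), read by radioligand binding; a higher number here means a weaker inhibitor, a lower number a stronger inhibitor. Compound 2 `Cc1ccc(C(=O)Nc2ccc3[nH]cc(C4CCN(C)CC4)c3n2)cc1` gives 12 nM in this assay, and it and compound 1 sit within the scatter of each other, so neither can be called the stronger. Among the measured compounds shown here, the one measured step, a 1.2-fold higher number from compound 1 to compound 2 (0.09 log units; within the scatter), shows that changing the group on the carbonyl carbon left the number essentially unchanged. Compound 3 `CCCC(=O)Nc1ccc2[nH]cc(C3CCN(C)CC3)c2n1` differs from compound 2 by propyl in place of 4-methylphenyl on a carbonyl carbon. Since the earlier exchange at the same place stayed within the scatter, the step of a 1.1-fold lower number from compound 2 to compound 3 (0.04 log units; within the scatter) is expected to do the same. Compound 3 is therefore estimated at 11 nM, within 4 nM to 30 nM.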

Compound 3, inhibition constant: 6.9 nM
For compound 3 the middle estimate is 1.6-fold (0.20 log units) above the measured one, and the stated range covers the measured number.
By their numbers in this assay, from the lowest: compounds 3, 1 and 2 (each within the scatter of the next).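

With propyl in place of 4-methylphenyl on the carbonyl carbon, the aromatic ring is gone, yet the step, a 1.7-fold lower number from compound 2 to compound 3 (0.24 log units; within the scatter), stays within the scatter. Propyl, an open chain with no ring, also stands level with cyclopropyl, at a 1.4-fold lower number from compound 1 to compound 3 (0.15 log units; within the scatter), so among these three compounds a ring on this carbonyl carbon makes no readable difference in this assay. No evidence is available on why these groups read alike. The compounds shown leave open whether a longer chain, an amine or a carboxylic acid on this carbonyl carbon would keep the number within the same scatter.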